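The compounds below may be only part of what the source reports. "The series", "measured", "known", "first", "only" and "open" are said of these compounds alone.

Working notes on the series sharing the core of compound 1 `N#CCC(=O)N/N=C1\C(=O)Nc2ccc(S(=O)(=O)N3CCOCC3)cc21`. In a functional assay on HepG2 cells (Homo sapiens) for cytotoxicity, read by sulforhodamine B assay, with a stated time of 24 h (on this read-out higher numbers stand for weaker inhibition and lower numbers for stronger inhibition), compound 1 gives 7530 nM. Compound 2 `N=c1oc2ccccc2cc1C(=O)N/N=C1\C(=O)Nc2ccc(S(=O)(=O)N3CCOCC3)cc21` carries a larger group on the carbonyl carbon and gives 7820 nM; the step of a 1.0-fold higher number from compound 1 to compound 2 (0.02 log units; within the scatter) is within the scatter. Compound 3 `O=C1Nc2ccc(S(=O)(=O)N3CCOCC3)cc2/C1=N/c1ccc(Br)cc1` replaces the acylhydrazone arm of compound 1 by 4-bromophenyl on the double-bonded nitrogen. In this assay compound 3 gives 11900 nM; the step of a 1.6-fold higher number from compound 1 to compound 3 (0.20 log units; within the scatter) is also within the scatter. On these three numbers compound 3 stands at the top end, but its distance to compound 2 and to compound 1 is within the scatter each time, so the three compounds read as one level in this assay.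

Compound 4 `O=C1Nc2ccc(S(=O)(=O)N3CCOCC3)cc2/C1=N/c1ccc(O)cc1` differs from compound 3 only in one place: hydroxy in place of bromo on an aromatic carbon. Going by the values given here, no measured pair in the set changes a substituent on this aromatic ring; the two measured steps concern the carbonyl carbon and the double-bonded nitrogen and say nothing about bromo against hydroxy here. Without a bearing step, the expectation is that the number of compound 4 stays within the scatter of compound 3, with no direction favoured, so the estimated step of a 1.1-fold lower number from compound 3 to compound 4 (0.03 log units; within the scatter) is small. Compound 4 is accordingly estimated at 11000 nM, with a range from 4000 nM to 30000 nM.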

Compound 4, half-maximal inhibitory concentration: 10400 nM
For compound 4 the middle estimate is 1.1-fold (0.02 log units) above the measured one, and the stated range covers the measured number.
By their numbers in this assay, from the lowest: compounds 1, 2, 4 and 3 (each within the scatter of the next).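

In this assay, going by these compounds alone, the exchange of 4-bromophenyl for 4-hydroxyphenyl gives a 1.1-fold lower number from compound 3 to compound 4 (0.06 log units; within the scatter) and is the first measured step on this aromatic carbon, para to a large group; it stays within the scatter even though a hydrogen-bond donor and a hydrogen-bond acceptor enter with the hydroxy, where the bromo brings neither. On the double-bonded nitrogen, the 4-hydroxyphenyl group of compound 4 set against the acylhydrazone arm of compound 1 gives a 1.4-fold higher number from compound 1 to compound 4 (0.14 log units; within the scatter) and also stays within the scatter, so this arm reads at the same level as the other two arms in the set. No accompanying measurement bears on what lies behind this level.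

On these data alone, whether an amine, a carboxylic acid or a methoxy group on the same aromatic carbon would also stay at this level remains open, as does the effect of moving the hydroxy to another carbon of the ring. Every step printed for these four compounds lies within the scatter, so none of them yet shows which groups at either place could move the number in a real way.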